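This account rests on a few compounds, and the source may have more. Where it says the series, first, only, none or still open, it means among the compounds named here.

In a functional assay on HepG2 cells (Homo sapiens) for inhibition, read by sulforhodamine B assay, with a stated time of 72 h (on this read-out higher numbers stand for weaker inhibition and lower numbers for stronger inhibition), compound 1 (`C[C@H](Nc1nc(N)nc(N)c1C#N)c1nn(-c2cccc(S(C)(=O)=O)c2)c2cc(F)ccc12`) gives 19100 nM and compound 2 (`C[C@H](Nc1ncnc2[nH]cnc12)c1nn(-c2cccnc2)c2ccc(F)cc12`) gives 41900 nM as the higher of the two numbers, so compound 2 is the weaker inhibitor by a margin beyond the scatter. Compound 3 (`Cc1ccc2c(c1)c([C@H](C)Nc1ncnc3[nH]cnc13)nn2-c1cccnc1`) carries methyl in place of fluoro on an aromatic carbon and is otherwise the same as compound 2. Within the data shown here, no measured step shows this change, so in this assay no shift beyond the scatter is expected, in either direction. The estimated step is a 1.1-fold lower number from compound 2 to compound 3 (0.04 log units; within the scatter) and thus small. Compound 3 is estimated at 38000 nM (expected range 15000 nM to 85000 nM).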

Compound 3, half-maximal inhibitory concentration: > 40000 nM
Compound 3: a limit, no number; the forecaster's own chance of this, stated with the estimate: 15%; middle value at least 1.0-fold (0.02 log units) from the limit.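

In this assay, among these compounds, compound 3 gives > 40000 nM, which is a limit and not a number, so no step from compound 2 to compound 3 can be read. The compounds shown leave open what methyl in place of fluoro on an aromatic carbon does to inhibition.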